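This account rests on a few compounds, and the source may have more. Where it says the series, first, only, none or still open, it means among the compounds named here.

Working notes on the series in a functional assay on LOX IMVI cells (Homo sapiens) for cytotoxicity, read by MTT assay, with a stated time of 24 h; on this read-out higher numbers stand for weaker inhibition and lower numbers for stronger inhibition. Compound 1 (`COc1cc(-c2nc(-c3ccccc3)[nH]c2-c2ccnc(NCCCNS(=O)(=O)c3ccc(C(F)(F)F)cc3)n2)ccc1F`) gives 75200 nM and compound 2 (`COc1cc(-c2nc(-c3ccccc3)[nH]c2-c2ccnc(NCCCNS(=O)(=O)c3ccc(C)cc3)n2)ccc1F`) gives 2590 nM. Among the compounds with values here, compound 2 therefore holds the lower of the two numbers so far, with compound 1 as its only neighbour. Within the data shown here, the one measured step is a 29-fold lower number from compound 1 to compound 2 (1.46 log units; beyond the scatter), with methyl in place of trifluoromethyl on an aromatic carbon.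

Compound 3 (`COc1ccc(S(=O)(=O)NCCCNc2nccc(-c3[nH]c(-c4ccccc4)nc3-c3ccc(F)c(OC)c3)n2)cc1`) changes the group at that same place: methoxy in place of methyl on an aromatic carbon. In words, this is methoxy in place of methyl on an aromatic carbon, para to a large group.

The measured step shows that the number in this assay can move strongly with the group at this place. However, it is a single step and involves neither the entering methoxy nor any close comparison for it. It gives no firm direction for the new change, so no step beyond the scatter is expected, with a slight lean towards a higher number.

The estimated step is a 1.4-fold higher number from compound 2 to compound 3 (0.13 log units; within the scatter). Compound 3 is expected at 3500 nM, with an estimated range of 1200 nM to 11000 nM.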

Compound 3, half-maximal inhibitory concentration: 6130 nM
Compound 3: the middle estimate sits 1.8-fold (0.24 log units) below what was measured; the range from low to high includes it.
By their numbers in this assay, from the lowest: compound 2; then compound 3; then compound 1.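

In this assay, the place on the sulfonyl-bound phenyl ring now carries three groups, and all three compounds are separated by steps beyond the scatter, with methyl giving the lowest number, then methoxy, then trifluoromethyl. Methoxy is a modest loss against methyl (a 2.4-fold higher number from compound 2 to compound 3 (0.37 log units; beyond the scatter)) but remains far better than trifluoromethyl (a 12-fold lower number from compound 1 to compound 3 (1.09 log units; beyond the scatter)), so the position tolerates an added oxygen with a much smaller penalty than the large rise seen for trifluoromethyl (a 29-fold lower number from compound 1 to compound 2 (1.46 log units; beyond the scatter)). No supporting data are available to explain this order, and three groups at one place are too few to define a trend beyond these compounds.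

The compounds shown leave open how an unsubstituted phenyl ring, a halogen such as chlorine, or an amine or a carboxylic acid at this place would compare with methyl, and whether anything gives a lower number than compound 2. They also leave open whether the same order of groups would hold with a longer chain between the sulfonamide and the shared core.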